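This account rests on a few compounds, and the source may have more. Where it says the series, first, only, none or still open, it means among the compounds named here.

Of the compounds shown here, three that share one core have been measured in an assay on Sf9 cells for inhibition of protein deacetylase HDAC6 (Homo sapiens), read by fluorescence, with a stated time of 40 min, tested at 100 nM; a lower number here means less inhibition, a higher number more inhibition at the concentration tested (going by the name of the read-out). Compound 1 `O=C(NO)c1ccc(NCc2nc(-c3cccc4cnccc34)nn2-c2ccccc2)cc1` gives 40.2%, compound 2 `O=C(NO)c1ccc(NCc2nc(-c3ccc(Br)cc3)nn2-c2ccccc2)cc1` gives 54.7%, and compound 3 `O=C(NO)c1ccc(NCc2nc(-c3ccc(C(F)(F)F)cc3)nn2-c2ccccc2)cc1` gives 41.6%. Compound 3 stands second highest of the three: its value lies within the scatter of that of compound 1, as the step of a number 1.4 percentage points higher from compound 1 to compound 3 (within the scatter) shows, while the step of a number 13.1 percentage points lower from compound 2 to compound 3 (beyond the scatter) is beyond the scatter. Compound 4 `O=C(NO)c1ccc(NCc2nc(-c3ccsc3)nn2-c2ccccc2)cc1` differs from compound 3 in one place: thiophen-3-yl in place of 4-(trifluoromethyl)phenyl on an aromatic carbon. Within the data shown here, no measured step introduces a thiophen-3-yl, so only the two steps that end at compound 3 bear on this change, and they show that swapping the group on this aromatic carbon has moved this assay by a modest amount at most. Compound 4 is therefore expected to give about 40%, within a range from 25% to 55%. The estimated step of a number 1.6 percentage points lower from compound 3 to compound 4 (within the scatter) is expected to remain within the scatter, with no clear direction.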

Compound 4, a percentage reported as inhibition, at one concentration (the size of the read-out at that concentration, not a potency): 53.4%
Beside the measured number, compound 4's estimate is 13.4 percentage points below it; the range from low to high includes it.
By their numbers in this assay, from the lowest: compounds 1 and 3 (each within the scatter of the next); then compounds 4 and 2 (each within the scatter of the next).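

In this assay, thiophen-3-yl on this aromatic carbon gives a number 11.8 percentage points higher from compound 3 to compound 4 (beyond the scatter) and a number 13.2 percentage points higher from compound 1 to compound 4 (beyond the scatter), but a number 1.3 percentage points lower from compound 2 to compound 4 (within the scatter). This shows that a five-membered aromatic ring with 1 hetero atom can take the place of a six-membered one at this position and still match the level of the 4-bromophenyl group, so the higher level is not confined to that group or to a six-membered ring. Nothing available explains why thiophen-3-yl and 4-bromophenyl stand together above 4-(trifluoromethyl)phenyl and isoquinolin-5-yl.

Every group shown at this position is an aromatic ring, so it remains open whether a ring is needed there at all, which an open chain such as butyl, an amine or a carboxylic acid could test. From the compounds shown here alone, it also remains open whether the other thiophene attachment, thiophen-2-yl, would read the same.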